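A Methyl Added to the Side-Chain Ether of Compound 1

This account rests on a few compounds, and the source may have more. Where it says the series, first, only, none or still open, it means among the compounds named here.

Measured so far:
compound 1, `COC(CC(=O)O)c1ccc(OCc2cccc(-c3c(C)cccc3C)c2)s1`, 210 nM
compound 2, `Cc1cccc(C)c1-c1cccc(OCc2cn(CCC(=O)O)nn2)c1`, 14700 nM
compound 3, `Cc1cccc(C)c1-c1cccc(COc2cn(CCC(=O)O)nn2)c1`, 14800 nM

In a functional assay on cells for agonist activity at Free fatty acid receptor 1 (Homo sapiens), read by calcium flux (on this read-out higher numbers stand for an effect only at larger amounts of compound and lower numbers for an effect already at smaller amounts), compound 1 gives 210 nM, the lowest of the three numbers and so the one acting at the smallest amount. Compound 2 with 14700 nM and compound 3 with 14800 nM sit far higher, both beyond the scatter.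

Compound 4, `CCOC(CC(=O)O)c1ccc(OCc2cccc(-c3c(C)cccc3C)c2)s1`, differs from compound 1 by methyl in place of hydrogen on a saturated chain carbon bound to an oxygen on a saturated carbon; read one bond further out, methoxy becomes ethoxy. Among the measured compounds shown here, no measured pair shows this change, so the expectation rests on compound 1 alone. The step is expected to be small, likely within the scatter, in either direction: a 1.1-fold lower number from compound 1 to compound 4 (0.02 log units; within the scatter). Compound 4 is therefore estimated at 200 nM, within a range of 70 nM to 600 nM.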

Compound 4, half-maximal effective concentration: 57 nM
For compound 4 the middle estimate is 3.5-fold (0.55 log units) above the measured one, and the stated range ends above it.
By their numbers in this assay, from the lowest: compound 4; then compound 1; then compounds 2 and 3 (each within the scatter of the next).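

In this assay, among the compounds shown here, the change from methoxy to ethoxy gives a 3.7-fold lower number from compound 1 to compound 4 (0.57 log units; beyond the scatter) and is the first single change that can be read here, since the earlier compounds offered no pair differing in one place. It shows that the saturated chain carbon bound to the ether oxygen responds to one added methyl, so this position is not indifferent to such a change. Nothing at hand explains the step. Going by these compounds, whether a longer chain such as propoxy would lower the number further remains open. So does what an isopropoxy group or a hydroxyl group would do at this position.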